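This account rests on a few compounds, and the source may have more. Where it says the series, first, only, none or still open, it means among the compounds named here.

Of the compounds shown here, three that share one core have been measured in an ADME assay on MRC5 cells (Homo sapiens) for inhibition, with a stated time of 72 h; a lower number here means that less compound is needed, a higher number that more compound is needed for the effect. Compound 1 `CO[C@H]1CC[C@H](NC(=O)c2n[nH]cc2NC(=O)c2ccc(-c3ccccc3)o2)CC1` gives 100 nM. Compound 3 `COc1cccc(OC)c1C(=O)Nc1c[nH]nc1C(=O)NC1CCN(Cc2ccccc2)C1` gives 38000 nM. Compound 2 `COc1cccc(OC)c1C(=O)Nc1c[nH]nc1C(=O)NN1CCOCC1` stands at a limit of the measurement, > 50000 nM, so no number for it is known. Going by the values given here, this is the limit of > 50000 nM in this assay, at which 1 of the 3 values shown sits, and it places compound 2 at the weak end of what has been measured, where compound 3 is the only other compound nearby.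

Compound 4 `COc1cccc(OC)c1C(=O)Nc1c[nH]nc1C(=O)Nc1ccccc1` has not been measured yet. It differs from compound 2 in one place: phenyl in place of morpholin-4-yl on an amide-type nitrogen. Among the compounds with values here, no pair of measured compounds differs in just one place, so the size of such a step cannot be read from the data. Most of the structure of compound 2 is shared by compound 3, which gives 38000 nM, and this suggests that compounds built like these two tend to need large amounts. For compound 4 a modest step toward needing less compound is expected, an at least 2.5-fold lower number from compound 2 to compound 4 (0.39 log units; beyond the scatter). Compound 4 is therefore estimated at 20000 nM, with a range from 5000 nM to 50000 nM.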

Compound 4, half-maximal effective concentration: > 50000 nM
Compound 4: a limit, no number; the forecaster's own chance of this, stated with the estimate: 35%; at least 2.5-fold (0.39 log units) between middle value and limit.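

Compound 4 gives > 50000 nM, which is a limit of the assay and not a number. Compound 2 stands at the same limit, so no step from one to the other can be read: the limit of > 50000 nM in this assay, at which 2 of the 4 values shown sit.

From the compounds shown here alone, whether phenyl and morpholin-4-yl on this amide-type nitrogen differ at all stays open.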